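Third fluoro on the aryl amine: outlook for compound 4

The compounds below may be only part of what the source reports. "The series", "measured", "known", "first", "only" and "open" are said of these compounds alone.

Measured compounds:
compound 1 `Cc1ccc(S(=O)(=O)/N=C(/CCNC2=CC(=O)c3ccccc3C2=O)Nc2ccc(Cl)cc2)cc1` — 7080 nM
compound 2 `Cc1ccc(S(=O)(=O)/N=C(/CCNC2=CC(=O)c3ccccc3C2=O)Nc2cccc(C)c2)cc1` — 8120 nM
compound 3 `Cc1ccc(S(=O)(=O)/N=C(/CCNC2=CC(=O)c3ccccc3C2=O)Nc2ccc(F)c(F)c2)cc1` — 9420 nM

In a functional assay on MCF7 cells (Homo sapiens) for cytotoxicity, read by MTT assay, with a stated time of 48 h (on this read-out higher numbers stand for weaker inhibition and lower numbers for stronger inhibition), the three measured compounds sit together. Compound 3 stands alongside compound 1 and compound 2: a 1.3-fold higher number from compound 1 to compound 3 (0.12 log units; within the scatter) and a 1.2-fold higher number from compound 2 to compound 3 (0.06 log units; within the scatter), both within the scatter, as is a 1.1-fold higher number from compound 1 to compound 2 (0.06 log units; within the scatter).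

Compound 4 `Cc1ccc(S(=O)(=O)/N=C(/CCNC2=CC(=O)c3ccccc3C2=O)Nc2cc(F)c(F)c(F)c2)cc1` differs from compound 3 by fluoro in place of hydrogen on an aromatic carbon. Every measured step in the series changes the aryl group on the amine nitrogen in the same way, and none of them moved the number beyond the scatter; the shared core with its sulfonyl and quinone parts is untouched. Among the compounds with values here, the closest precedent is compound 3 itself, where two fluoro groups on that ring gave a number indistinguishable from the chloro and methyl analogues. Compound 4 is therefore expected to fall in the same band, with a 1.1-fold higher number from compound 3 to compound 4 (0.03 log units; within the scatter) as the expected step. The estimate for compound 4 is 10000 nM, with a range of 5000 nM to 20000 nM.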

Compound 4, half-maximal inhibitory concentration: 6610 nM
The estimate for compound 4 lay 1.5-fold (0.18 log units) above the measured number; low and high end bracket the measured number.
By their numbers in this assay, from the lowest: compounds 4, 1, 2 and 3 (each within the scatter of the next).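

In this assay, fluoro in place of hydrogen on the aromatic carbon ortho to a fluoro group gives a 1.4-fold lower number from compound 3 to compound 4 (0.15 log units; within the scatter) and so shows that this position accepts a third fluoro with no step beyond the scatter. The 3,4,5-trifluorophenyl group also sits level with the other aryl groups, with a 1.2-fold lower number from compound 2 to compound 4 (0.09 log units; within the scatter) for the change from 3-methylphenyl and a 1.1-fold lower number from compound 1 to compound 4 (0.03 log units; within the scatter) for the change from 4-chlorophenyl, so all four aryl groups shown remain indistinguishable. No measurement at hand bears on why this step stays so small.

From the compounds shown here alone, whether this position stays as tolerant with a methoxy group, an amine or a carboxylic acid in place of the fluoro remains open. Also open, going by these compounds, is whether a longer chain in the shared core would move the number beyond the scatter in this assay or leave it level.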